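Working notes: from compound 2 to compound 3

The compounds below may be only part of what the source reports. "The series", "measured", "known", "first", "only" and "open" are said of these compounds alone.

Measured in an ADME assay for permeability, using PAMPA, at pH 4; a higher number here means that the compound crosses the layer faster, a lower number that the compound crosses the layer more slowly:
Compound 1 `CCc1c(C)[nH]c2cc(OC)c(Cl)cc2c1=O`: 96.4 10^-6 cm/s
Compound 2 `C=C(CCCCC)c1c(C)[nH]c2cc(OC)c(Cl)cc2c1=O`: 768 10^-6 cm/s

Of the two measured compounds, compound 2 has the higher number, at 768 10^-6 cm/s. Among the compounds with values here, the only measured step is an 8.0-fold higher number from compound 1 to compound 2 (0.90 log units; beyond the scatter), and it lies beyond the scatter.

The next compound is compound 3 `CCCCC/C=C/c1c(C)[nH]c2cc(OC)c(Cl)cc2c1=O`, which has not yet been measured in this assay. The change is a group of 7 heavy atoms (7 carbon; no ring) in place of a group of 7 heavy atoms (7 carbon; no ring), on an aromatic carbon. The two compounds have the same atoms, joined differently, and the group stays on the same aromatic carbon.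

The measured step bears on this change only loosely, since it replaced a smaller group with a larger one, whereas here the counts stay the same. Within the data shown here, no measured pair shows what a rearrangement of the same atoms does, so the direction remains open. No step beyond the scatter is expected, and compound 2 at 768 10^-6 cm/s serves as the anchor. The expected change is a 1.2-fold lower number from compound 2 to compound 3 (0.07 log units; within the scatter). For compound 3 the estimated value is 650 10^-6 cm/s, with an expected range of 270 10^-6 cm/s to 1400 10^-6 cm/s.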

Compound 3, apparent permeability: 280 10^-6 cm/s
Estimate against measurement, compound 3: 2.3-fold (0.37 log units) above; the range from low to high includes it.
By their numbers in this assay, from the lowest: compound 1; then compound 3; then compound 2.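

In this assay, the aromatic carbon carrying this group responds to how the atoms of the group are joined, not only to how many there are: with the atoms unchanged, hept-1-en-1-yl in place of the other group of 7 carbon atoms gives a 2.7-fold lower number from compound 2 to compound 3 (0.44 log units; beyond the scatter) and so lies beyond the scatter. The gain over ethyl survives this rearrangement in reduced form, as hept-1-en-1-yl in place of ethyl gives a 2.9-fold higher number from compound 1 to compound 3 (0.46 log units; beyond the scatter), set against an 8.0-fold higher number from compound 1 to compound 2 (0.90 log units; beyond the scatter) for the other group of 7 carbon atoms, which leaves compound 3 between the other two in the order of numbers. No measurement in hand accounts for either step, nor for the difference between the two isomeric groups.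

Three compounds leave open whether the double bond or its place in the chain governs this difference, and a saturated heptyl chain would bear directly on that question. Going by these compounds, how a shorter alkenyl chain, or a chain ending in an amine or a carboxylic acid, would behave at this position also remains open, as does whether the same order would hold on a different core.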